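Swapping an Amine Side Chain for Chlorine on a Fused Core

A few compounds are considered here, and "the series" means these few. Any claim that something is new, unique, unknown or untested is made for them only; others in the source may bear on it.

Compound 1 `CC(C)COc1ccc2c(Cl)ccnc2c1`: 2680 nM
Compound 2 `CN(C)CCNc1ccnc2cc(OCc3ccccc3)ccc12`: 2350 nM
Compound 3 `C=CCOc1ccc2c(NCCN(C)C)ccnc2c1`: 1270 nM

In a functional assay on RKO cells (Homo sapiens) for cytotoxicity, read by MTT assay, with a stated time of 48 h (on this read-out lower numbers stand for stronger inhibition and higher numbers for weaker inhibition), compound 3 gives 1270 nM, the lowest of the three numbers. Compound 2 sits closest, and the step of a 1.9-fold lower number from compound 2 to compound 3 (0.27 log units; within the scatter) is within the scatter. Compound 1 lies furthest away, beyond the scatter.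

Compound 4 `C=CCOc1ccc2c(Cl)ccnc2c1` differs from compound 3 in one place: chloro in place of (2-(dimethylamino)ethyl)amino on an aromatic carbon. For the measured compounds named here, no measured step covers this change. Going by the values given here, the one step on record, from compound 2 to compound 3, concerns the chain on the oxygen, not this position. Compound 1 carries the same chloro at this place but also a different chain on the oxygen, so only its value can be set beside compound 3.

Compound 4 is therefore expected to land close to compound 1 because compound 1 with the same chloro gives 2680 nM. The step of a 1.7-fold higher number from compound 3 to compound 4 (0.24 log units; within the scatter) is expected to be a modest rise in the number, possibly within the scatter. The estimate for compound 4 is 2200 nM, with a range from 800 nM to 6000 nM.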

Compound 4, half-maximal inhibitory concentration: 2460 nM
Beside the measured number, compound 4's estimate is 1.1-fold (0.05 log units) below it, and the stated range covers the measured number.
By their numbers in this assay, from the lowest: compounds 3, 2, 4 and 1 (each within the scatter of the next, the first and the last beyond it).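

In this assay, for the compounds shown here, the first direct reading at this aromatic carbon, opposite the ring nitrogen, is a 1.9-fold higher number from compound 3 to compound 4 (0.29 log units; within the scatter), so exchanging the (2-(dimethylamino)ethyl)amino side chain for a single chloro leaves a difference that repeated measurements could not separate from noise. The chain on the oxygen can now also be read with chloro at this carbon, and a 1.1-fold lower number from compound 1 to compound 4 (0.04 log units; within the scatter) is likewise a step that does not stand out from the scatter. Nothing measured on these compounds offers an explanation for either step.

On these data alone, whether a shorter amine such as plain amino, or a longer chain ending in a morpholine ring, would give a step beyond the scatter at this carbon stays open. So does whether a carboxylic acid there would do so.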